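A few compounds are considered here, and "the series" means these few. Any claim that something is new, unique, unknown or untested is made for them only; others in the source may bear on it.

Series notes. In an assay on cells for inhibition of protein deacetylase HDAC6 (Homo sapiens), read by fluorescence, with a stated time of 24 h (a higher number here means a weaker inhibitor, a lower number a stronger inhibitor), compound 1 `C[C@@H](NC(=O)c1nc(-c2nccs2)sc1C1CC1)c1ccc(C(=O)NO)cc1` gives 211 nM. For the measured compounds named here, compound 2 `C[C@H](NC(=O)c1nc(-c2nc3c(s2)CCCC3)sc1C1CC1)c1ccc(C(=O)NO)cc1`, which carries the bicyclic fused aryl group and the opposite configuration at the stereocentre, gives 18.3 nM in this assay, the lowest of the two numbers measured so far; the gap to compound 1 lies beyond the scatter, but two structural features differ at once, so the two values say nothing separately about either.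

Compound 3 `C[C@H](NC(=O)c1nc(-c2nccs2)sc1C1CC1)c1ccc(C(=O)NO)cc1` keeps the configuration of compound 2 and replaces the aryl substituent: a group of 5 heavy atoms (3 carbon, 1 nitrogen, 1 sulfur; one five-membered aromatic ring with 2 hetero atoms) in place of a group of 9 heavy atoms (7 carbon, 1 nitrogen, 1 sulfur; one five-membered aromatic ring with 2 hetero atoms, one six-membered non-aromatic ring of carbon only), on an aromatic carbon. Going by the values given here, no pair of measured compounds isolates this change. The expectation is a step upward in this assay of moderate size, a 4.4-fold higher number from compound 2 to compound 3 (0.64 log units; beyond the scatter), short of the whole gap seen between compound 2 and compound 1, since the configuration is held. Compound 3 is estimated at 80 nM in this assay, with a range from 25 nM to 250 nM.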

Compound 3, half-maximal inhibitory concentration: 14 nM
For compound 3 the middle estimate is 5.7-fold (0.76 log units) above the measured one; measured number below the stated range.
By their numbers in this assay, from the lowest: compounds 3 and 2 (each within the scatter of the next); then compound 1.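

Compounds 1 and 3 form a pair that isolates the stereocentre at the saturated chain carbon: in this assay there is a 15-fold lower number from compound 1 to compound 3 (1.18 log units; beyond the scatter), with the S configuration as drawn on the lower side. At this aromatic carbon, with the S configuration held, 1,3-thiazol-2-yl in place of the larger fused group gives a 1.3-fold lower number from compound 2 to compound 3 (0.12 log units; within the scatter), so the extra six-membered non-aromatic ring carries no difference that can be read in this assay. The large step can be assigned to the stereocentre alone because no other part of the structure changes: the fact that compounds 1 and 3 differ only in the configuration as drawn

The compounds shown leave open how the fused group behaves in the R configuration. Also open, from the compounds shown here alone, is whether a phenyl ring, an amine or a longer alkyl chain on this aromatic carbon would stay within the scatter of compound 3.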